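The source may report more compounds than this note shows. Statements on the series, on what has been measured and on what is new or still open speak of the compounds shown alone.

In an assay on isolated protein for activation of Nicotinamide phosphoribosyltransferase (Homo sapiens) (on this read-out lower numbers stand for an effect already at smaller amounts and higher numbers for an effect only at larger amounts of compound), the compounds measured so far are:
compound 1, `O=C(NCc1ccncc1)Nc1ccc(S(=O)(=O)Nc2ccccc2)cc1`: 410 nM;
compound 2, `O=C(NCc1ccncc1)Nc1ccc(S(=O)(=O)c2ccccc2Cl)cc1`: 79 nM;
compound 3, `CCOC(=O)c1ccc(N(C)C(=O)NCc2ccncc2)cc1`: > 100000 nM, a limit of the assay and not a number.

Compound 2 stands at the lowest of the two numbers in this assay. For the measured compounds named here, its nearest neighbour is compound 1, and the single measured step, a 5.2-fold lower number from compound 1 to compound 2 (0.72 log units; beyond the scatter), is modest and beyond the scatter. For compound 3 only a limit is known (the limit of > 100000 nM in this assay, at which 1 of the 3 values shown sits).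

Compound 4, `NS(=O)(=O)c1ccc(NC(=O)NCc2ccncc2)cc1`, differs from compound 2 by amino in place of 2-chlorophenyl on a sulfonyl sulfur. Going by the values given here, no measured step covers this change: the one step known, a 5.2-fold lower number from compound 1 to compound 2 (0.72 log units; beyond the scatter), exchanges one aryl group on the sulfonyl sulfur for another, whereas here the aryl group is removed altogether. The account therefore expects a step in this assay towards a higher number, larger than the measured step, with wide uncertainty. Compound 4 is expected to give 3000 nM in this assay, between 500 nM and 20000 nM. That corresponds to an expected step of a 38-fold higher number from compound 2 to compound 4 (1.58 log units; beyond the scatter).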

Compound 4, half-maximal effective concentration: 14300 nM
The estimate for compound 4 lay 4.8-fold (0.68 log units) below the measured number; the measured number falls inside the stated range.
By their numbers in this assay, from the lowest: compound 2; then compound 1; then compound 4. At a limit, above all of these: compound 3.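

In this assay, amino in place of 2-chlorophenyl on a sulfonyl sulfur gives a 180-fold higher number from compound 2 to compound 4 (2.26 log units; beyond the scatter). Hydrogen in place of phenyl on a sulfonamide nitrogen gives a 35-fold higher number from compound 1 to compound 4 (1.54 log units; beyond the scatter), so this place tolerates more than one aromatic-ring-bearing group, while compound 4, which has no ring there, carries a much higher number than either compound 1 or compound 2, a change far larger than the modest exchange seen earlier. Nothing available here gives a reason for the size of these steps.

From the compounds shown here alone, whether the aromatic ring itself counts, or any carbon group on the sulfonyl sulfur would serve, stays open; a methyl group, a cyclohexyl ring or a piperidine there would tell these apart. Also open, going by these compounds, is what the chlorine contributes, which an unsubstituted phenyl on the sulfonyl sulfur would show.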